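A few compounds are considered here, and "the series" means these few. Any claim that something is new, unique, unknown or untested is made for them only; others in the source may bear on it.

Measured in an ADME assay on C8166 cells (Homo sapiens) for cytotoxicity, read by MTT assay, with a stated time of 3 days; a lower number here means that less compound is tolerated, a higher number that more compound is tolerated:
- compound 1 `COc1ccc(CNC(=O)c2nc(C(C)(C)NC(=O)OCc3ccccc3)nc(O)c2O)cc1`: 164000 nM
- compound 2 `CC(C)(NC(=O)OCc1ccccc1)c1nc(O)c(O)c(NC(=O)NCc2ccc(F)cc2)n1`: 81100 nM
- compound 3 `CC(C)(NC(=O)OCc1ccccc1)c1nc(O)c(O)c(C(=O)NCC2CC2)n1`: 204000 nM

Among the measured compounds shown here, compound 3 carries the largest of the three numbers, though its difference to compound 1 lies within the scatter; compound 2 alone sits lower by a margin beyond the scatter, and no single-point step links compound 2 to compound 3.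

Compound 4 `CC(C)(NC(=O)OCc1ccccc1)c1nc(O)c(O)c(C(=O)NCc2ccccc2)n1` differs from compound 3 by phenyl in place of cyclopropyl on a saturated chain carbon bound to an amide-type nitrogen. For the measured compounds named here, the one step that bears on this place is a 1.2-fold higher number from compound 1 to compound 3 (0.09 log units; within the scatter), an exchange of an aryl for the cyclopropyl at the same carbon that left the number within the scatter. Putting phenyl back in place of cyclopropyl is therefore expected to give no step beyond the scatter in this assay, a 1.1-fold lower number from compound 3 to compound 4 (0.05 log units; within the scatter). For compound 4 the estimate is 180000 nM, range 90000 nM to 360000 nM.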

Compound 4, half-maximal cytotoxic concentration: 41400 nM
Beside the measured number, compound 4's estimate is 4.3-fold (0.64 log units) above it, outside the stated range (below it).
By their numbers in this assay, from the lowest: compounds 4 and 2 (each within the scatter of the next); then compounds 1 and 3 (each within the scatter of the next).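

In this assay the group on the saturated chain carbon is not freely exchangeable: phenyl in place of cyclopropyl gives a 4.9-fold lower number from compound 3 to compound 4 (0.69 log units; beyond the scatter) and so moves the number beyond the scatter, which the earlier 4-methoxyphenyl to cyclopropyl exchange did not. The methoxy also counts, as hydrogen in its place on the aromatic carbon gives a 4.0-fold lower number from compound 1 to compound 4 (0.60 log units; beyond the scatter) and separates phenyl from 4-methoxyphenyl. Nothing on hand explains either step.

Open, on these data alone, is whether an amine or a carboxylic acid on that aromatic carbon would behave like methoxy or like hydrogen. Also open, as far as these compounds go, is how a longer chain in place of cyclopropylmethyl or benzyl would read here.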